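Allyl for Isopropyl on the Amine of Compound 3

The source may report more compounds than this note shows. Statements on the series, on what has been measured and on what is new or still open speak of the compounds shown alone.

Measured compounds:
compound 1 `Nc1ncnc2c1ncn2[C@@H]1O[C@H](CSCCCC(=O)O)[C@@H](O)[C@H]1O` — no result reported
compound 2 `NCCCSC[C@H]1O[C@@H](n2cnc3c(N)ncnc32)[C@H](O)[C@@H]1O` — no result reported
compound 3 `CC(C)N(CC[C@H](N)C(=O)O)C[C@H]1O[C@@H](n2cnc3c(N)ncnc32)[C@H](O)[C@@H]1O` — 44%

The series was examined in an assay for inhibition of tRNA (cytosine(38)-C(5))-methyltransferase (Homo sapiens), with a stated time of 5 min, tested at 100 uM; a higher number here means more inhibition at the concentration tested (going by the name of the read-out), a lower number less inhibition. Compound 1 `Nc1ncnc2c1ncn2[C@@H]1O[C@H](CSCCCC(=O)O)[C@@H](O)[C@H]1O` gives no result reported and compound 2 `NCCCSC[C@H]1O[C@@H](n2cnc3c(N)ncnc32)[C@H](O)[C@@H]1O` gives no result reported, so neither carries a number. Among the compounds with values here, compound 3 `CC(C)N(CC[C@H](N)C(=O)O)C[C@H]1O[C@@H](n2cnc3c(N)ncnc32)[C@H](O)[C@@H]1O` is therefore the only member with a number: in this assay compound 3 gives 44%, a moderate inhibition at the single concentration tested. Within the data shown here, with one value in hand, no step between measured compounds can be described and no pattern can be claimed.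

Compound 4 `C=CCN(CC[C@H](N)C(=O)O)C[C@H]1O[C@@H](n2cnc3c(N)ncnc32)[C@H](O)[C@@H]1O` is the next point. It differs from compound 3 in a single place: allyl in place of isopropyl on an amine nitrogen. The leaving and entering groups are both three carbons, the entering one carrying a double bond outside aromatic rings, and neither adds a donor, an acceptor or a charge.

Since nothing in the data indicates how this assay responds to such an exchange, the expected step from compound 3 to compound 4 is small, a number 4 percentage points lower from compound 3 to compound 4 (within the scatter), and is not expected to reach beyond the usual scatter in either direction. Compound 4 is accordingly estimated at 40%, with a plausible range from 20% to 60%.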

Compound 4, a percentage reported as inhibition, at one concentration (the size of the read-out at that concentration, not a potency): 53.9%
Estimate against measurement, compound 4: 13.9 percentage points below; the range from low to high includes it.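

In this assay, allyl in place of isopropyl on the amine nitrogen gives a number 9.9 percentage points higher from compound 3 to compound 4 (within the scatter), so this assay does not separate the two groups at this position. The nitrogen, whose other neighbours are saturated chain carbons, can therefore carry either three-carbon group, and a double bond outside aromatic rings in that group leaves the reading within the usual scatter at the single concentration tested. No measurement at hand accounts for the reading at this position.

On these data alone, whether a longer chain, a benzyl group or a plain hydrogen on this nitrogen would give a step beyond the scatter remains open. So does the part played by the carboxylic acid and the primary amine of the shared side chain, for which no comparison can be read among the compounds shown.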